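The compounds below may be only part of what the source reports. "The series", "measured", "known", "first", "only" and "open" are said of these compounds alone.

Going by the values given here, in a functional assay on A20 cells (Mus musculus) for inhibition, with stated times of 1 h, 16 h and 24 h (a higher number here means a weaker inhibitor, a lower number a stronger inhibitor), compound 2 (`N#CC1(NC(=O)[C@@H]2C[C@@H](S(=O)(=O)c3ccccc3)C[C@H]2C(=O)N2CCCCC2)CC1`) gives 5 nM, the higher of the two numbers so far, while compound 1 (`C[C@@H]1CN(C(=O)[C@@H]2C[C@H](S(=O)(=O)c3ccccc3)C[C@H]2C(=O)NC2(C#N)CC2)C[C@H](C)O1`) gives 1 nM. Compound 3 (`CC1CCN(C(=O)[C@@H]2C[C@H](S(=O)(=O)c3ccccc3)C[C@H]2C(=O)NC2(C#N)CC2)CC1`) changes piperidin-1-yl to 4-methylpiperidin-1-yl: methyl in place of hydrogen on a saturated ring carbon. This is methyl in place of hydrogen on a saturated ring carbon, three ring bonds from the ring nitrogen.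

Among the compounds with values here, only one measured step bears on this change: a 5.0-fold higher number from compound 1 to compound 2 (0.70 log units; beyond the scatter), modest and beyond the scatter. It shows that the ring on this carbonyl carbon can move the number, and the methyl-bearing ring of compound 1 holds the lower value. The guide is weak, since those two rings differ by more than methyl groups and no single methyl change has been measured in this assay. A small move toward a lower number is therefore expected, smaller than the measured step and possibly within the scatter. The expected change is a 1.7-fold lower number from compound 2 to compound 3 (0.22 log units; within the scatter). For compound 3 the estimated value is 3 nM, with an expected range of 1 nM to 10 nM.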

Compound 3, half-maximal inhibitory concentration: 2 nM
For compound 3 the middle estimate is 1.5-fold (0.18 log units) above the measured one, and the stated range covers the measured number.
By their numbers in this assay, from the lowest: compounds 1 and 3 (each within the scatter of the next); then compound 2.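

In this assay, going by these compounds alone, this is the first single methyl change, and it gives a 2.5-fold lower number from compound 2 to compound 3 (0.40 log units; beyond the scatter) on a saturated ring carbon, three ring bonds from the ring nitrogen. One methyl at this place is therefore enough to move the number beyond the scatter, which the earlier step of a 5.0-fold higher number from compound 1 to compound 2 (0.70 log units; beyond the scatter) could not show, since those two rings differ in more than methyl groups. Replacing 2,6-dimethylmorpholin-4-yl with 4-methylpiperidin-1-yl gives a 2.0-fold higher number from compound 1 to compound 3 (0.30 log units; within the scatter) and so does not separate these two rings in this assay. No measurement on hand accounts for either new step.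

The compounds shown leave open how the number responds when this methyl gives way to ethyl, a longer chain, a hydroxyl group or an amine. They also leave open whether the methyl step holds when a pyridine ring stands in place of the phenyl group of the shared core.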